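Methyl in place of hydrogen on the shared core

The source may report more compounds than this note shows. Statements on the series, on what has been measured and on what is new or still open speak of the compounds shown alone.

Values so far in a physicochemical assay for lipophilicity, at pH 7.4 (a higher number here means a more lipophilic compound, a lower number a more polar compound), for three compounds
compound 1 `CN(Cc1ccc2nccn2c1)c1nnc(-c2ccc(-c3ccccc3Cl)nc2)o1` gives 3.3 as its number
compound 2 `CNC(=O)c1sc(N2CC3CC2(CNC(=O)c2c[nH]c4ncc(C(F)(F)F)cc24)C3)nc1C(F)(F)F` gives 4.2 as its number
compound 3 `CNC(=O)c1sc(N2CC3CC2(CNC(=O)c2c[nH]c4ncccc24)C3)nc1C(F)(F)F` gives 3.1 as its number

In this assay compound 3 lies within the scatter of compound 1 and clearly under compound 2. Compound 4 `CNC(=O)c1sc(N2CC3CC2(CNC(=O)c2c[nH]c4ncc(C)cc24)C3)nc1C(F)(F)F` has no number yet. Its change from compound 3 is methyl in place of hydrogen on an aromatic carbon and falls on an aromatic carbon of a six-membered aromatic ring with 1 nitrogen, two atoms from the ring nitrogen. Compound 2 carries trifluoromethyl at that same place.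

Going by the values given here, one measured step bears on this change: a number 1.10 log units lower from compound 2 to compound 3 (beyond the scatter) on going from trifluoromethyl to hydrogen. That step is large, and read backwards it shows a rise when a group replaces hydrogen at this place. Among the compounds with values here, no compound with methyl there has been measured, and a single step sets no general rule. A rise smaller than that one is expected. The estimated step is a number 0.50 log units higher from compound 3 to compound 4 (beyond the scatter) in this assay for this change. For compound 4 the estimated value is 3.6 with an expected range from 3.3 to 3.9 on the same scale.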

Compound 4, distribution coefficient: 3.5
Compound 4: the middle estimate sits 0.10 log units above what was measured; the measured number falls inside the stated range.
By their numbers in this assay, from the lowest: compounds 3, 1 and 4 (each within the scatter of the next, the first and the last beyond it); then compound 2.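

In this assay, this position now has three measured groups on the shared core, which fall in the order hydrogen, methyl, trifluoromethyl. Methyl in place of hydrogen gives a number 0.40 log units higher from compound 3 to compound 4 (beyond the scatter), and methyl in place of trifluoromethyl gives a number 0.70 log units lower from compound 2 to compound 4 (beyond the scatter), so both steps are beyond the scatter and methyl stands apart from each of the other two groups. The earlier step gave only the two ends of this span, whereas methyl now provides a point inside it, although nothing measured here gives a reason for the order or for where methyl falls.

From the compounds shown here alone, compound 2, compound 3 and compound 4 differ only at this one place on one core, so whether the same order holds on another core remains open, and compound 1 offers no comparison with them. Also open, going by these compounds, is what a chlorine atom, a methoxy group or an amine at this place would give in this assay, and whether a longer chain such as ethyl would extend the rise seen with methyl.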